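Ester to Trifluoromethoxy: One Change, One Expected Value

This account rests on a few compounds, and the source may have more. Where it says the series, first, only, none or still open, it means among the compounds named here.

Compound 1 `Cc1cc(=O)oc2cc(Sc3cccc(Cl)[n+]3[O-])ccc12` reaches in a functional assay on DU-145 cells (Homo sapiens) for antiproliferative activity, read by sulforhodamine B assay, with a stated time of 72 h (on this read-out higher numbers stand for weaker inhibition of growth and lower numbers for stronger inhibition of growth), only a limit, > 31200 nM.
Compound 2 `Cc1cc(=O)oc2cc(SC3CCOC3=O)ccc12` reaches in this assay only a limit, > 36100 nM.
Compound 3 `COC(=O)c1cccc(CSc2ccc3c(C)cc(=O)oc3c2)c1` gives in this assay 14100 nM.

Among the three measured compounds, compound 3 is the only one with an actual number; for compound 1 the reading stops at a limit (the limit of > 31200 nM in this assay, at which 1 of the 3 values shown sits), and for compound 2 likewise (the limit of > 36100 nM in this assay, at which 1 of the 3 values shown sits). Compound 3 therefore stands alone as the one point from which a comparison can start.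

Compound 4 `Cc1cc(=O)oc2cc(SCc3cccc(OC(F)(F)F)c3)ccc12` differs from compound 3 in a single place: trifluoromethoxy in place of methoxycarbonyl on an aromatic carbon. Within the data shown here, no measured pair in this set shows a change of this kind, so the data give no size for such a step. The step from compound 3 to compound 4 in this assay is expected to be small, a 1.3-fold lower number from compound 3 to compound 4 (0.11 log units; within the scatter), within the usual scatter or close to it. For compound 4 the estimated value is 11000 nM, expected to lie between 3500 nM and 35000 nM.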

Compound 4, concentration for 50% growth inhibition: 15500 nM
Compound 4: middle estimate off by 1.4-fold (0.15 log units), on the low side, and the stated range covers the measured number.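

In this assay, replacing methoxycarbonyl with trifluoromethoxy on this aromatic carbon gives a 1.1-fold higher number from compound 3 to compound 4 (0.04 log units; within the scatter). Among these compounds, this is the first measured step in the set, and it puts a size on a change at this position: two groups that differ in their atoms and in their count of hydrogen-bond acceptors cannot be told apart on this read-out. Nothing shown here explains why the two values stay so close.

One pair cannot show how other groups would behave at this position, so an amine or a carboxylic acid on the same aromatic carbon could give a similar number or a very different one. As far as these compounds go, it also remains open whether a longer chain in place of either group would shift the value beyond the scatter.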